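The source may report more compounds than this note shows. Statements on the series, on what has been measured and on what is new or still open speak of the compounds shown alone.

In a physicochemical assay for solubility, read by HPLC, in phosphate buffer, measured as kinetic solubility, with a stated time of 1 h, at pH 7.4, tested at 250 uM (on this read-out higher numbers stand for higher solubility and lower numbers for lower solubility), compound 1 `CC(=O)N1CCC(c2ccc3c(c2)oc(=O)n3C(=O)NCCCCc2ccccc2)CC1` is reported only as a limit, < 1000 nM, so its true solubility is not pinned down by a number; this is the limit described in the limit of < 1000 nM in this assay, at which 1 of the 3 values shown sits. Two other compounds give a sense of the range of this assay. Compound 2 `O=C(NCCCCc1ccccc1)n1c2c(oc1=O)CNCC2`, which carries a smaller ring system in place of the substituted fused core, gives 230000 nM in this assay. Compound 3 `CC(C)CNC(=O)n1c(=O)oc2cc(C3CCCN(C)C3)ccc21` is reported only as a limit, > 250000 nM, the limit described in the limit of > 250000 nM in this assay, at which 1 of the 3 values shown sits. No direct pairwise comparison among these three is available, so they show only that readings spread from the lower limit to the upper limit.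

The next compound, compound 4 `CN1CCN(c2ccc3c(c2)oc(=O)n3C(=O)NCCCCc2ccccc2)CC1=O`, differs from compound 1 in one place: 4-methyl-3-oxopiperazin-1-yl in place of 1-acetylpiperidin-4-yl on an aromatic carbon. Because compound 1 sits at the limit < 1000 nM, the step can only be read as an expectation. A modest rise in solubility is expected, of the size an at least 3.0-fold higher number from compound 1 to compound 4 (0.47 log units; beyond the scatter), though a reading at the same limit remains quite possible. Compound 4 is therefore estimated at 3000 nM, within a range from 500 nM to 30000 nM.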

Compound 4, solubility: < 1000 nM
Compound 4: no number, only a limit; the forecaster's own chance of this, stated with the estimate: 40%; middle value at least 3.0-fold (0.47 log units) from the limit.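

Compound 4 gives < 1000 nM as a limit and not as a number. Among the compounds shown here, compound 1 also stands at a limit, and no step between compound 1 and compound 4 can be read. On these data alone, how far the true solubilities of compound 1 and compound 4 differ, if at all, stays open.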